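The compounds below may be only part of what the source reports. "The series", "measured", "known", "first", "only" and "open" are said of these compounds alone.

Measured compounds:
compound 1, `CCOc1ccc2c(c1)OC(c1ccccc1)C(c1ccccc1)C2=O`, giving 877000 nM
compound 2, `CCOc1ccc2c(c1)OC(c1ccc([N+](=O)[O-])cc1)C(c1ccccc1)C2=O`, giving > 2500000 nM

In a functional assay (a lower number here means that less compound is needed, a higher number that more compound is needed for the effect), compound 1 gives 877000 nM. For compound 2 the assay reports only a limit, > 2500000 nM, so its true value is not known. The step of an at least 2.8-fold higher number from compound 1 to compound 2 (0.45 log units; beyond the scatter) is thus a lower bound on the change, resting on (the limit of > 2500000 nM in this assay, at which 1 of the 2 values shown sits).

Compound 3, `CCOc1ccc2c(c1)OC(c1ccc(Cl)cc1)C(c1ccccc1)C2=O`, has not been measured. It differs from compound 2 by chloro in place of nitro on an aromatic carbon, para to a large group. Among the measured compounds shown here, only one measured step touches this position, an at least 2.8-fold higher number from compound 1 to compound 2 (0.45 log units; beyond the scatter), where nitro in place of hydrogen pushed the number up beyond the scatter and onto the limit. Removing the nitro again, now for chloro, is expected to bring the number back part of the way toward compound 1, and the expectation for compound 3 is an at least 1.6-fold lower number from compound 2 to compound 3 (0.22 log units; that floor lies within the scatter) in this assay. The size of this expected step remains uncertain, as the measurement of compound 2 is only a limit. Compound 3 is therefore estimated at 1500000 nM in this assay, with a range from 600000 nM to 4000000 nM.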

Compound 3, half-maximal effective concentration: 578000 nM
Compound 3: the middle estimate sits 2.6-fold (0.41 log units) above what was measured; measured number outside the range, below it.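

In this assay, this position, para to a large group, can now be compared with three different groups on it: hydrogen, nitro and chloro. Not every group placed here raises the number, since chloro in place of hydrogen gives a 1.5-fold lower number from compound 1 to compound 3 (0.18 log units; within the scatter), so compound 1 and compound 3 cannot be told apart in this assay, while the change from nitro to chloro gives an at least 4.3-fold lower number from compound 2 to compound 3 (0.63 log units; beyond the scatter). The high number therefore goes with the nitro group in this small set rather than with any group at this position, and the true size of the step away from nitro stays unknown, as it is only a lower bound: the limit of > 2500000 nM in this assay, at which 1 of the 3 values shown sits.

The compounds shown leave open whether nitro stands alone or whether other groups at this position, such as an amine or a carboxylic acid, would also push the number up. They also leave open whether a change elsewhere on the shared core, such as a longer chain, would move the number further than any swap at this position.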